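A few compounds are considered here, and "the series" means these few. Any claim that something is new, unique, unknown or untested is made for them only; others in the source may bear on it.

Measured in a functional assay on HT-29 cells (Homo sapiens) for inhibition, read by sulforhodamine B assay, with a stated time of 48 h; a higher number here means a weaker inhibitor of growth, a lower number a stronger inhibitor of growth:
- compound 1 `CCOC(=O)c1nn(-c2ccc(Cl)cc2)c(-c2ccc(Cl)cc2)c1CNC(C)(C)C`: 57700 nM; > 519000 nM (2 entries)
- compound 2 `CC(C)(C)NCc1c(C(=O)O)nn(-c2ccccc2)c1-c1ccc(Cl)cc1`: 353000 nM
- compound 3 `CC(C)(C)NCc1c(C(=O)O)nn(-c2ccc(Cl)cc2)c1-c1ccc(F)cc1`: > 623000 nM

Compound 3 stands at > 623000 nM, which is a limit of the assay and not a number. The same reading appears in the limit of > 623000 nM in this assay, at which 1 of the 3 values shown sits. The record for compound 1 is also mixed, as the several entries of compound 1 in this assay, 57700 nM; > 519000 nM (2 entries) holds one number and one limit.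

Compound 4 `CC(C)(C)NCc1c(C(=O)O)nn(-c2ccc(Cl)cc2)c1-c1ccc(Cl)cc1` differs from compound 3 in one place, chloro in place of fluoro on an aromatic carbon, para to a large group, so 4-fluorophenyl becomes 4-chlorophenyl. Within the data shown here, no measured pair shows this exchange in this assay. No change beyond the scatter is therefore expected, and no direction can be assigned with confidence. Another limit reading is about as likely as a number. The expectation of weak growth inhibition rests on compound 2 at 353000 nM. The estimated step is an at least 1.5-fold lower number from compound 3 to compound 4 (0.19 log units; that floor lies within the scatter). For compound 4 the estimate is 400000 nM, with an expected range of 150000 nM to 800000 nM.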

Compound 4, concentration for 50% growth inhibition: > 599000 nM
Compound 4: only a limit was reported; the forecaster's own chance of this, stated with the estimate: 50%; middle value at least 1.4-fold (0.17 log units) away from the limit.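

In this assay compound 4 gives > 599000 nM, which is a limit of the assay and not a number. With compound 3 also recorded only as a limit, the step from 4-fluorophenyl to 4-chlorophenyl cannot be read, so this position has still given no number for either group. Among these compounds, the only readable step is an at least 1.6-fold higher number from compound 2 to compound 4 (0.22 log units; that floor lies within the scatter), and with its floor within the scatter, it shows no change beyond the scatter.

From the compounds shown here alone, whether a methoxy or an amine at this position would give a number instead of a limit remains open. Also open, going by these compounds, is whether fluoro and chloro differ here at all, which would need a number for compound 3 and for compound 4.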